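The source may report more compounds than this note shows. Statements on the series, on what has been measured and on what is new or still open speak of the compounds shown alone.

Measured compounds: compound 1 `OCc1ccc(-c2ccc3c(O)cccc3c2)cc1` gives 14%; compound 2 `N#Cc1ccc(-c2ccc3c(O)cccc3c2)cc1` gives 16%. Compound 3 `Oc1cccc2cc(-c3ccncc3)ccc12` reaches only a limit of the assay, < 10%.

In an assay for binding affinity to 17-beta-hydroxysteroid dehydrogenase type 1 (Homo sapiens), with a stated time of 20 min, tested at 1 uM (a lower number here means less inhibition, a higher number more inhibition at the concentration tested (going by the name of the read-out)), compound 1 stands at the lowest of the two numbers shown, but the step of a number 2 percentage points higher from compound 1 to compound 2 (within the scatter) lies within the scatter, so the two are not distinguished. Compound 3 sits at the limit of < 10% in this assay, at which 1 of the 3 values shown sits.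

Compound 4 `CNC(=O)c1ccc(-c2ccc3c(O)cccc3c2)cc1` differs from compound 1 by methylcarbamoyl in place of hydroxymethyl on an aromatic carbon. Among the compounds with values here, the only measured step at this position, a number 2 percentage points higher from compound 1 to compound 2 (within the scatter), exchanged the same hydroxymethyl for cyano and stayed within the scatter, so no step beyond the scatter is expected in this assay either. Compound 4 is therefore estimated to give 15%, between 5% and 30%. The expected step of a number 1 percentage points higher from compound 1 to compound 4 (within the scatter) thus remains within the scatter.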

Compound 4, a percentage reported as inhibition, at one concentration (the size of the read-out at that concentration, not a potency): < 10%
Compound 4 ended at the assay's limit; the forecaster's own chance of this, stated with the estimate: 30%; at least 5 percentage points between middle value and limit.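

In this assay compound 4 gives < 10%, which is a limit of the assay and not a number. At this position, para to a large group, methylcarbamoyl gives a number at least 4 percentage points lower from compound 1 to compound 4 (that floor lies within the scatter) and a number at least 6 percentage points lower from compound 2 to compound 4 (that floor lies within the scatter); neither floor passes the scatter, so this position has still shown no change that stands clear of it. The limit now holds more of the series: the limit of < 10% in this assay, at which 2 of the 4 values shown sit.

From the compounds shown here alone, how far compound 4 really lies from compound 1 and compound 2 stays open. Also open, going by these compounds, is how an amine or a carboxylic acid on this aromatic carbon would read in this assay.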